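Removing the Pentafluoroethyl Group: An Estimate for Compound 3

A few compounds are considered here, and "the series" means these few. Any claim that something is new, unique, unknown or untested is made for them only; others in the source may bear on it.

Going by the values given here, compound 2 `C/N=C(/S)C1=CC(C)(C)Oc2ccc(C(F)(F)C(F)(F)F)cc21` gives 12.6 nM in a functional assay (aorta) with Rattus norvegicus as the target (on this read-out lower numbers stand for an effect already at smaller amounts and higher numbers for an effect only at larger amounts of compound), the lower of the two numbers measured so far, although its only neighbour, compound 1 `C/N=C(/S)C1=CC(C)(C)Oc2ccc(C#N)cc21`, gives 24.6 nM and the gap is within the scatter. Among the compounds with values here, the single measured step, a 2.0-fold lower number from compound 1 to compound 2 (0.29 log units; within the scatter), swapped one group for another at the same place. Compound 3 `C/N=C(/S)C1=CC(C)(C)Oc2ccccc21` differs from compound 2 by hydrogen in place of 1,1,2,2,2-pentafluoroethyl on an aromatic carbon. That earlier swap says little about losing the group altogether, so the expectation rests on caution alone. Compound 3 is expected to sit at 50 nM, a step of a 4.0-fold higher number from compound 2 to compound 3 (0.60 log units; beyond the scatter), with a range from 15 nM to 200 nM.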

Compound 3, half-maximal effective concentration: 4270 nM
For compound 3 the middle estimate is 85-fold (1.93 log units) below the measured one; the measured number lies above the stated range.
By their numbers in this assay, from the lowest: compounds 2 and 1 (each within the scatter of the next); then compound 3.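

Putting hydrogen on this aromatic carbon gives a 340-fold higher number from compound 2 to compound 3 (2.53 log units; beyond the scatter) in this assay, and replacing cyano with hydrogen gives a 170-fold higher number from compound 1 to compound 3 (2.24 log units; beyond the scatter). The earlier swap between two groups hid this dependence: having either group here, rather than hydrogen, counts for far more than which of the two is present. Nothing shown explains why the loss is so large.

Going by these compounds, whether a methyl group, an amine or a carboxylic acid on this carbon would keep the low numbers remains open. So does whether the same group would work elsewhere on the ring.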